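Methyl added to the shared core of compound 2

The compounds below may be only part of what the source reports. "The series", "measured", "known", "first", "only" and "open" are said of these compounds alone.

Two compounds built on a shared core carrying a 2,5-dimethoxyphenylthio group have been measured in an assay on HEK293 cells for inhibition of Leucine-rich repeat serine/threonine-protein kinase 2 (Homo sapiens), read by ELISA, with a stated time of 90 min; a higher number here means a weaker inhibitor, a lower number a stronger inhibitor. Compound 1 `COc1ccc(OC)c(Sc2ccc3nnc(-c4ccsn4)n3n2)c1` gives 722 nM in this assay. Compound 2 `COc1ccc(OC)c(Sc2ccc3ncc(-c4cnn(C)c4)n3n2)c1` gives 400 nM in this assay. On the numbers shown, compound 2 stands at the low end, but its gap to compound 1 lies within the scatter, so the two figures cannot be told apart.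

Compound 3 `COc1ccc(OC)c(Sc2ccc3nc(C)c(-c4cnn(C)c4)n3n2)c1` has not yet been measured in this assay. It differs from compound 2 by a single change: methyl in place of hydrogen on an aromatic carbon. Among the measured compounds shown here, no pair of measured compounds differing in one place exists here, so there is no measured step to lean on. A single methyl on an aromatic carbon of the shared core is a small change, and in this assay the expectation is for a step of a 1.1-fold lower number from compound 2 to compound 3 (0.02 log units; within the scatter), roughly no change beyond the scatter in either direction. Compound 3 is therefore expected to give about 380 nM in this assay, with a range from 150 nM to 950 nM.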

Compound 3, half-maximal inhibitory concentration: 945 nM
Compound 3: middle estimate off by 2.5-fold (0.40 log units), on the low side; measured number inside the range.
By their numbers in this assay, from the lowest: compounds 2, 1 and 3 (each within the scatter of the next, the first and the last beyond it).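

In this assay, among the compounds shown here, this is the first change that can be read on its own, since compound 1 and compound 2 differ in more than one place. Methyl in place of hydrogen on this aromatic carbon, next to the ring atom that bears a 1-methyl-1H-pyrazol-4-yl group, gives a 2.4-fold higher number from compound 2 to compound 3 (0.37 log units; beyond the scatter) and so marks a modest loss of inhibition. The position therefore does not stay neutral to even this one added carbon, and among the compounds shown nothing measured accounts for the step.

From the compounds shown here alone, a single methyl gives only one point at this position, so it remains open whether the number would rise further with a longer chain such as ethyl, or whether an amine or a methoxy group on the same carbon would move it in the same direction. Going by these compounds, it is also open whether the step holds when the 1-methyl-1H-pyrazol-4-yl group or the 2,5-dimethoxyphenylthio group is replaced, since both stay fixed across compound 2 and compound 3.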